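A few compounds are considered here, and "the series" means these few. Any claim that something is new, unique, unknown or untested is made for them only; others in the source may bear on it.

Measured so far in an ADME assay on KB cells (Homo sapiens) for cytotoxicity; on this read-out lower numbers stand for an effect already at smaller amounts and higher numbers for an effect only at larger amounts of compound:

compound 1 `COc1cc2c(c(OC)c1OC)C(=O)[C@]1(OC)C=C[C@H]2N(C(=O)OCC(C)C)N1C(=O)OCC(C)C`: > 300 ug/mL
compound 2 `CCOC(=O)N1[C@@H]2C=C[C@@](OC)(C(=O)c3c2cc(OC)c(OC)c3OCc2ccccc2F)N1C(=O)OCC`: 99.7 ug/mL
compound 3 `COC(=O)N1[C@@H]2C=C[C@@](OC)(C(=O)c3c2cc(OC)c(OC)c3OCc2ccc(Cl)cc2)N1C(=O)OC`: 55.9 ug/mL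

Compound 1 sits at the limit of this assay; its entry is a bound rather than a number (the limit of > 300 ug/mL in this assay, at which 1 of the 3 values shown sits). Compound 2 and compound 3 each return a number inside the measured range, and both carry an aromatic ring on the chain carbon bound to the ring oxygen of the core, where compound 1 carries only a methyl. Within the data shown here, no step between measured compounds is available, so the move from compound 1 to compound 4 has no directly matching precedent in the set, and the carbamate chains of compound 2 and compound 3 are not those of compound 1.

Compound 4 `COc1cc2c(c(OCc3ccc(F)cc3)c1OC)C(=O)[C@]1(OC)C=C[C@H]2N(C(=O)OCC(C)C)N1C(=O)OCC(C)C` differs from compound 1 by 4-fluorophenyl in place of hydrogen on a saturated chain carbon bound to an oxygen on an aromatic ring.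

Because compound 2 gives 99.7 ug/mL and compound 3 gives 55.9 ug/mL in this assay, the step of an at least 3.3-fold lower number from compound 1 to compound 4 (0.52 log units; beyond the scatter) is expected to run downward, into a measurable number, and beyond the usual scatter. Compound 4 is therefore estimated at 90 ug/mL, with a range from 30 ug/mL to 300 ug/mL, while a repeat of a bare limit remains a real possibility.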

Compound 4, concentration for half-maximal effect: > 300 ug/mL
Compound 4 ended at the assay's limit; the forecaster's own chance of this, stated with the estimate: 25%; at least 3.3-fold (0.52 log units) between middle value and limit.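

No step can be read from compound 1 to compound 4, since the entries for both compounds are limits and not numbers: the limit of > 300 ug/mL in this assay, at which 2 of the 4 values shown sit.

The compounds shown leave open whether 4-fluorophenyl in place of hydrogen on a saturated chain carbon bound to an oxygen on an aromatic ring changes the read-out at all with the carbamate chains of compound 1.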